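The compounds below may be only part of what the source reports. "The series", "measured", "known", "first", "only" and "open" are said of these compounds alone.

Working notes on the series. The shared core of compound 1 `COc1cc(N2C(N)=C(C#N)C(c3c(OC)ccc4ccccc34)C3=C2CC(C)(C)CC3=O)cc(OC)c1OC` is kept throughout; the compounds differ only in the group on a saturated ring carbon. In a functional assay on Ehrlich cells (Mus musculus) for cytotoxicity, tested at 50 ug/mL (on this read-out lower numbers stand for a weaker effect and higher numbers for a stronger effect at the one concentration tested), compound 1 gives 10%. Compound 2 `COc1cc(N2C(N)=C(C#N)C(c3ccccc3O)C3=C2CC(C)(C)CC3=O)cc(OC)c1OC` gives 2%, and compound 3 `COc1cc(N2C(N)=C(C#N)C(c3cccc([N+](=O)[O-])c3)C3=C2CC(C)(C)CC3=O)cc(OC)c1OC` gives 30%. Compound 3 thus stands highest of the three measured compounds: the step of a number 20 percentage points higher from compound 1 to compound 3 (beyond the scatter) and the step of a number 28 percentage points higher from compound 2 to compound 3 (beyond the scatter) both lie beyond the scatter, while the step of a number 8 percentage points lower from compound 1 to compound 2 (within the scatter) stays within it.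

Compound 4 `COc1cc(N2C(N)=C(C#N)C(c3ccc(C)o3)C3=C2CC(C)(C)CC3=O)cc(OC)c1OC` is not yet measured. Its change from compound 3: 5-methylfuran-2-yl in place of 3-nitrophenyl on a saturated ring carbon. All three measured steps are swaps of the group on this same saturated ring carbon, so all bear on it; two of them were modest and one was within the scatter. Of the three measured groups, only 3-nitrophenyl gave a value clearly above the others, and 5-methylfuran-2-yl is another departure from it, so a downward step in this assay is expected for compound 4, back toward the range of compound 1 and compound 2, with wide uncertainty. The expected step is a number 18 percentage points lower from compound 3 to compound 4 (beyond the scatter). For compound 4 the estimated value is 12%, with a range from 0% to 35%.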

Compound 4, a percentage reported as activity, at one concentration (the size of the read-out at that concentration, not a potency): 41%
Compound 4: middle estimate off by 29 percentage points, on the low side; the measured number lies above the stated range.
By their numbers in this assay, from the lowest: compounds 2 and 1 (each within the scatter of the next); then compound 3; then compound 4.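

At this saturated ring carbon, the step in this assay to 5-methylfuran-2-yl is a number 11 percentage points higher from compound 3 to compound 4 (beyond the scatter) and is also a number 31 percentage points higher from compound 1 to compound 4 (beyond the scatter) and a number 39 percentage points higher from compound 2 to compound 4 (beyond the scatter), which places compound 4 highest among the four compounds. The higher numbers at this position are therefore not confined to 3-nitrophenyl: a five-membered aromatic ring with 1 hetero atom, and with no nitrogen in the group, exceeds that six-membered aromatic ring of carbon only, while the other two six-membered carbon-ring groups, in compound 1 and compound 2, remain the lowest. Nothing measured alongside these numbers accounts for the step to compound 4.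

The compounds shown leave open whether the furan ring or its methyl group carries the step, a question that furan-2-yl without the methyl, 5-methylthiophen-2-yl or a saturated tetrahydrofuran-2-yl would address. They also leave open whether the order seen at the one concentration tested would hold across a range of concentrations.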